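The source may hold more compounds than are shown below. What is called first, only, known or untested is meant among the compounds shown, and "the series" means these compounds.

In a functional assay on cells (Neutrophil, Homo sapiens) for inhibition, with a stated time of 10 min (on this read-out higher numbers stand for weaker inhibition and lower numbers for stronger inhibition), compound 1, with the structure `CCOC(=O)c1cnn(CC(C)O)c1NC(=O)Nc1cccc(F)c1`, gives 0.0007 nM. Compound 2, with the structure `CCOC(=O)c1cnn(CC(O)CC)c1NC(=O)Nc1cccc(F)c1`, gives 0.36 nM in this assay. The difference between them is hydrogen in place of methyl on a saturated chain carbon, two bonds along the chain from an oxygen on a saturated carbon, and the step it made was a 510-fold lower number from compound 2 to compound 1 (2.71 log units; beyond the scatter).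

Compound 3, with the structure `CCCC(O)Cn1ncc(C(=O)OCC)c1NC(=O)NCc1ccccc1`, gives 0.0032 nM in this assay. Its number is lower than that of compound 2 and higher than that of compound 1. The difference between the core of compound 3 and the core of compound 2 is not broken down here.

Compound 4, with the structure `CCOC(=O)c1cnn(CC(O)CC)c1NC(=O)NCc1ccccc1`, has not yet been measured. It differs from compound 3 by hydrogen in place of methyl on a saturated chain carbon, three bonds along the chain from an oxygen on a saturated carbon. Within the data shown here, this is the same kind of change as the one from compound 2 to compound 1, but not the same: there the place was two bonds along the chain from an oxygen on a saturated carbon, here it is three bonds along the chain from that oxygen. Among the measured compounds shown here, because the only measured example of this kind of change is a 510-fold lower number from compound 2 to compound 1 (2.71 log units; beyond the scatter), a lowering of the number from compound 3 to compound 4 is expected, but because the place is not the same, a smaller step than that one is expected, estimated at a 3.2-fold lower number from compound 3 to compound 4 (0.51 log units; beyond the scatter). In this assay compound 4 is therefore expected to give about 0.001 nM, most likely between 0.0001 nM and 0.01 nM.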

Compound 4, half-maximal inhibitory concentration: 0.0074 nM
For compound 4 the middle estimate is 7.4-fold (0.87 log units) below the measured one; the range from low to high includes it.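

In this assay, taking one carbon off the chain does not act alike on the two cores: the same change on two cores in this assay, a 510-fold lower number (2.71 log units; beyond the scatter) from compound 2 to compound 1 and a 2.3-fold higher number (0.36 log units; beyond the scatter) from compound 3 to compound 4, 1200-fold (3.08 log units) apart, beyond the scatter of two such steps

The cores differ by benzyl in place of 3-fluorophenyl on an amide-type nitrogen, a swap that gives a 49-fold lower number from compound 2 to compound 4 (1.69 log units; beyond the scatter), and with benzyl present the shorter chain gives a 2.3-fold higher number from compound 3 to compound 4 (0.36 log units; beyond the scatter), a modest step in the opposite direction to the large one seen with 3-fluorophenyl. This does not show that the core alone decides the outcome: the carbon also leaves from a different place in the two pairs, two bonds along the chain from the oxygen in one and three bonds along it in the other, and each result rests on a single pair.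

Still open, as far as these compounds go, is how benzyl on the amide-type nitrogen behaves with the chain of compound 1, and how 3-fluorophenyl behaves with the chain of compound 3, two combinations that would help separate the effect of the core from that of the place. Also open, from the compounds shown here alone, is what a longer chain, or an amine or a carboxylic acid in place of the hydroxyl group, would do on either core.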